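Compound 3 to compound 4: exchange on a carbonyl carbon

This account rests on a few compounds, and the source may have more. Where it says the series, first, only, none or still open, it means among the compounds named here.

Of the compounds shown here, three have been measured so far: compound 1 `Cc1c2c(n3c1CCCN(C)[C@@H](C)[C@H](C)Nc1cc-3ccc1C(N)=O)CC(C)(C)CC2=O`, compound 2 `COCCC(=O)N1CCCc2c(C)c3c(n2-c2ccc(C(N)=O)c(c2)N[C@@H](C)[C@@H]1C)CC(C)(C)CC3=O` and compound 3 `CC[C@H](N)C(=O)N1CCc2c(C)c3c(n2-c2ccc(C(N)=O)c(c2)N[C@@H](C)[C@H](C)C1)CC(C)(C)CC3=O`. In a functional assay on HCT-116 cells (Homo sapiens) for antiproliferative activity (on this read-out lower numbers stand for stronger inhibition and higher numbers for weaker inhibition), compound 1 gives 51 nM, compound 2 gives 55 nM and compound 3 gives 33 nM. Compound 3 has the lowest of the three numbers, but it lies within the scatter of both others, so the set shows no real separation.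

The next compound is compound 4 `Cc1c2c(n3c1CCN(C(=O)[C@@H](O)C(C)C)C[C@@H](C)[C@H](C)Nc1cc-3ccc1C(N)=O)CC(C)(C)CC2=O`. It carries 1-hydroxy-2-methylpropyl in place of 1-aminopropyl on a carbonyl carbon whose other neighbour is an amide-type nitrogen in a ring: 1-hydroxy-2-methylpropyl in place of 1-aminopropyl on a carbonyl carbon.

Among the measured compounds shown here, only one measured step bears on this change. That step, a 1.1-fold higher number from compound 1 to compound 2 (0.03 log units; within the scatter), puts (2-methoxyethyl)carbonyl in place of methyl on an amine nitrogen in a ring, and it stays within the scatter. For the measured compounds named here, it is indirect evidence, as no measured pair exchanges one carbonyl substituent for another. With that caveat, no shift beyond the scatter is expected in this assay, and no direction is favoured with any confidence. The expected change is a 1.2-fold higher number from compound 3 to compound 4 (0.08 log units; within the scatter). In this assay, compound 4 is estimated at 40 nM, with an expected range of 15 nM to 110 nM.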

Compound 4, half-maximal inhibitory concentration: 45 nM
Estimate against measurement, compound 4: 1.1-fold (0.05 log units) below, and the stated range covers the measured number.
By their numbers in this assay, from the lowest: compounds 3, 4, 1 and 2 (each within the scatter of the next).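

Among the compounds shown here, this is the first measured exchange directly on the carbonyl carbon whose other neighbour is an amide-type nitrogen in a ring; the earlier step concerned an amine nitrogen in a ring. In this assay, the step is a 1.4-fold higher number from compound 3 to compound 4 (0.13 log units; within the scatter) and lies within the scatter, so this position accepts 1-hydroxy-2-methylpropyl as well as 1-aminopropyl without a separation in the read-out. The nitrogen of the leaving group is therefore not required for a number in this range, at least in this pair, where the entering group has oxygen instead of nitrogen, 5 heavy atoms instead of 4, and the same count of hydrogen-bond donors and acceptors. Nothing measured here explains this result.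

For the compounds shown here, the single step changes the heteroatom and the carbon branching together, so the contribution of each remains unresolved. Also open, on these data alone, is whether a carboxylic acid, a longer alkyl chain or a phenyl ring on this carbonyl carbon would give a step beyond the scatter, or whether this position stays as accepting across such groups.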